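Lengthening the chain once more in a cyanoguanidine series

A few compounds are considered here, and "the series" means these few. Any claim that something is new, unique, unknown or untested is made for them only; others in the source may bear on it.

Compound 1, `N#CNC(=N)NCCCn1nc(-c2ccccc2)ccc1=O`, in a functional assay on the whole organism (stomach) with Rattus norvegicus as the target (a higher number here means that more compound is needed for the effect, a lower number that less compound is needed), gives > 100 mg/kg, which is a limit of the assay and not a number.
Compound 2, `C/N=C(\NC#N)NCCCCn1nc(-c2ccccc2)ccc1=O`, in this assay gives 32.4 mg/kg.
Compound 3, `C/N=C(/NC#N)NCCCn1nc(-c2ccccc2)ccc1=O`, in this assay gives > 100 mg/kg, again a limit of the assay and not a number.

Among the measured compounds shown here, compound 2 therefore stands as the only compound with a number; the other two values are limits, as summed up by the limit of > 100 mg/kg in this assay, at which 2 of the 3 values shown sit. The unmeasured compound 4, `C/N=C(/NC#N)NCCCCCn1nc(-c2ccccc2)ccc1=O`, differs from compound 2 by a group of 8 heavy atoms (4 carbon, 4 nitrogen; no ring) in place of a group of 7 heavy atoms (3 carbon, 4 nitrogen; no ring), on a saturated chain carbon, four bonds along the chain from an aromatic nitrogen.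

For the measured compounds named here, two measured steps bear on this change, as both concern the chain between the shared core and the cyanoguanidine. The step of an at least 3.0-fold lower number from compound 1 to compound 2 (0.48 log units; beyond the scatter) and the step of an at least 3.0-fold higher number from compound 2 to compound 3 (0.48 log units; beyond the scatter) both point the same way: the longer chain of compound 2 gives the lower number, while the shorter chains sit at the limit. Whether a still longer chain continues the trend or reverses it cannot be read from these three compounds, since both steps end at a limit and leave the size unreadable.

Compound 4 is therefore expected to land near compound 2, at an estimated 30 mg/kg with a range from 10 mg/kg to 100 mg/kg, which means an expected step of a 1.1-fold lower number from compound 2 to compound 4 (0.03 log units; within the scatter).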

Compound 4, dose for half-maximal effect: 100 mg/kg
The estimate for compound 4 lay 3.3-fold (0.52 log units) below the measured number, within the range that was stated.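

Going beyond the chain of compound 2 did not lower the number further in this assay: the change brought a 3.1-fold higher number from compound 2 to compound 4 (0.49 log units; beyond the scatter), so more compound was needed for the effect. The earlier compounds showed only that the shorter chain of compound 3 was worse, with an at least 3.0-fold higher number from compound 2 to compound 3 (0.48 log units; beyond the scatter), whereas compound 2 now has steps beyond the scatter on both the shorter and the longer side, making its chain the best of the lengths shown in this assay. The step between compounds whose values both sit at a limit cannot be read, so the series gives no finer order at that end, because those values are not numbers: the limit of > 100 mg/kg in this assay, at which 2 of the 4 values shown sit.

The compounds shown leave open whether a still longer chain would keep raising the number or level off, and whether the trend holds with a urea or an amide in place of the cyanoguanidine. They also leave open whether a branched chain or a chain carrying an ether oxygen, at the length of compound 2, would give a lower number than compound 2, which gives 32.4 mg/kg in this assay.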